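Hydroxy to chloro on the aryl ring: an expected step

The compounds below may be only part of what the source reports. "The series", "measured", "known", "first", "only" and "open" are said of these compounds alone.

Compound 1, `COc1ccc(C(=O)/C=C/c2cc3ccccc3[nH]c2=O)cc1`, in a functional assay on NCI-H226 cells (Homo sapiens) for cytotoxicity, read by sulforhodamine B assay, with a stated time of 24 h (a lower number here means a stronger inhibitor of growth, a higher number a weaker inhibitor of growth), gives > 100000 nM, which is a limit of the assay rather than a number.
Compound 2, `O=C(/C=C/c1cc2ccccc2[nH]c1=O)c1ccc(O)cc1`, in this assay gives 10900 nM.

For the measured compounds named here, compound 2 thus holds the only true number here; the other value is a limit. Compound 3, `O=C(/C=C/c1cc2ccccc2[nH]c1=O)c1ccc(Cl)cc1`, differs from compound 2 by chloro in place of hydroxy on an aromatic carbon. Going by the values given here, the single measured step, an at least 9.1-fold lower number from compound 1 to compound 2 (0.96 log units; beyond the scatter), came from hydrogen replacing methyl on the ring oxygen. Compound 3 removes the hydroxy entirely, so a weaker inhibitor is expected, with wide uncertainty: the step is expected to be a 2.8-fold higher number from compound 2 to compound 3 (0.44 log units; beyond the scatter). Compound 3 is estimated at 30000 nM, between 8000 nM and 100000 nM.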

Compound 3, concentration for total growth inhibition: 38900 nM
Compound 3: the middle estimate sits 1.3-fold (0.11 log units) below what was measured, within the range that was stated.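

Chloro in place of hydroxy on this aromatic carbon, para to a large group, gives a 3.6-fold higher number from compound 2 to compound 3 (0.55 log units; beyond the scatter) in this assay. Chloro in place of methoxy gives an at least 2.5-fold lower number from compound 1 to compound 3 (0.41 log units; beyond the scatter), so among these three groups the order runs hydroxy, chloro, methoxy. The size of that last step stays open-ended, because compound 1 stands at a limit of the assay: the limit of > 100000 nM in this assay, at which 1 of the 3 values shown sits.

Whether the hydrogen-bond donor, which only hydroxy carries here, explains this order remains open. So does where an amine or a carboxylic acid at this position would fall.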